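The compounds below may be only part of what the source reports. "The series", "measured", "known", "first", "only" and "open" are said of these compounds alone.

Of the compounds shown here, three sharing one core have been tested in a functional assay on DLD-1 cells (Homo sapiens) for cytotoxicity, with a stated time of 48 h; on this read-out higher numbers stand for weaker inhibition and lower numbers for stronger inhibition. Compound 1 `CC(=O)Oc1ccc2oc(/C=C/[S+](C)[O-])cc(=O)c2c1` reports only a limit, > 10000 nM. Compound 2 `C[S+]([O-])/C=C/c1cc(=O)c2cc(F)ccc2o1` gives 7000 nM. Compound 3 `CC(C)C(=O)Oc1ccc2oc(/C=C/[S+](C)[O-])cc(=O)c2c1` gives 9100 nM, and the gap between these two numbers is a 1.3-fold higher number from compound 2 to compound 3 (0.11 log units; within the scatter). Compound 4 `CCCOc1ccc2oc(/C=C/[S+](C)[O-])cc(=O)c2c1` carries propyl in place of isopropylcarbonyl on an oxygen on an aromatic ring. The measured steps that alter this group are an at least 1.4-fold lower number from compound 1 to compound 2 (0.15 log units; that floor lies within the scatter), an at least 1.0-fold lower number from compound 1 to compound 3 (0.04 log units; that floor lies within the scatter) and the step already given for compound 3, and none goes beyond the scatter. No step beyond the scatter is therefore expected, and the estimated step is a 1.1-fold lower number from compound 3 to compound 4 (0.03 log units; within the scatter). For compound 4 the expected value is 8500 nM, with an estimated range of 4000 nM to 16000 nM.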

Compound 4, half-maximal inhibitory concentration: 6200 nM
Estimate against measurement, compound 4: 1.4-fold (0.14 log units) above; low and high end bracket the measured number.
By their numbers in this assay, from the lowest: compounds 4, 2 and 3 (each within the scatter of the next). At a limit, above all of these: compound 1.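

In this assay, replacing the isopropylcarbonyl on this oxygen with propyl removes the carbonyl, yet the result is a 1.5-fold lower number from compound 3 to compound 4 (0.17 log units; within the scatter), so an ether here reads the same as the ester of compound 3. Swapping the whole propoxy group for fluoro changes no more: the step is a 1.1-fold lower number from compound 2 to compound 4 (0.05 log units; within the scatter). The step involving the acetyl ester is an at least 1.6-fold lower number from compound 1 to compound 4 (0.20 log units; that floor lies within the scatter), only a floor, because compound 1 stands at a limit: the limit of > 10000 nM in this assay, at which 1 of the 4 values shown sits.

Still open, from the compounds shown here alone, is whether a longer chain, or an amine or carboxylic acid on this oxygen, would give a step beyond the scatter.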